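This account rests on a few compounds, and the source may have more. Where it says the series, first, only, none or still open, it means among the compounds named here.

Measured so far:
compound 1 `CN(c1ccccc1)c1cnc(NCc2c(F)ccc3c2CCO3)n2cnnc12`: 3.6
compound 2 `CN(c1ncco1)c1cnc(NCc2c(F)ccc3c2CCO3)n2cnnc12`: 2.1

In a physicochemical assay for lipophilicity, using the shake flask method, in phosphate buffer, measured as octanol-water partition, with a stated time of 30 min, at pH 7.4 (a higher number here means a more lipophilic compound, a lower number a more polar compound), compound 2 gives the lowest of the two numbers, with compound 1 the nearest, a step of a number 1.50 log units lower from compound 1 to compound 2 (beyond the scatter). Compound 3 `CN(c1cccnc1)c1cnc(NCc2c(F)ccc3c2CCO3)n2cnnc12` differs from compound 2 by pyridin-3-yl in place of 1,3-oxazol-2-yl on a nitrogen on an aromatic ring. Within the data shown here, no measured step shows this exact change; the only step at this nitrogen swaps phenyl for 1,3-oxazol-2-yl, and it was large, so the six-membered ring with one hetero atom is expected to land between the two measured points. Compound 3 is expected to give 2.5 in this assay, within 2 to 3, a step of a number 0.40 log units higher from compound 2 to compound 3 (beyond the scatter).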

Compound 3, distribution coefficient: 2.6
Compound 3: middle estimate off by 0.10 log units, on the low side; the range from low to high includes it.
By their numbers in this assay, from the lowest: compound 2; then compound 3; then compound 1.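

In this assay the change to pyridin-3-yl on this nitrogen gives a number 0.50 log units higher from compound 2 to compound 3 (beyond the scatter) and also a number 1.00 log units lower from compound 1 to compound 3 (beyond the scatter) as a second reading. The three aromatic rings on this nitrogen therefore give three separate numbers, none within the scatter of another, and the six-membered ring with one hetero atom stands apart from both phenyl and 1,3-oxazol-2-yl. Nothing available explains this order.

The compounds shown leave open how a saturated amine such as piperidine, or a longer alkyl chain, would read on this nitrogen in this assay here. They also leave open whether pyridin-2-yl or pyridin-4-yl would match pyridin-3-yl.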